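Swapping the Amide-Side Ring in an Adenosine-Derived Series

The compounds below may be only part of what the source reports. "The series", "measured", "known", "first", "only" and "open" are said of these compounds alone.

Compound 1 `Nc1ncnc2c1ncn2[C@@H]1O[C@H](CSCC[C@H](N)C(=O)NCc2ccccc2)[C@@H](O)[C@H]1O` and compound 2 `CN1CCn2nc(CNC(=O)[C@@H](N)CCSC[C@H]3O[C@@H](n4cnc5c(N)ncnc54)[C@H](O)[C@@H]3O)cc2C1` share the same core, a sugar-linked adenine joined through a sulfur-bearing chain to an amino acid amide, and differ only in the group on the saturated chain carbon bound to the amide-type nitrogen. In an assay on Sf9 cells for inhibition of histone-lysine N-methyltransferase EZH2 (Homo sapiens), read by scintillation counting, in the presence of a further agent that is not named here (on this read-out higher numbers stand for weaker inhibition and lower numbers for stronger inhibition), compound 1 gives 120000 nM, while compound 2 gives 50000 nM. The measured step here was a 2.4-fold lower number from compound 1 to compound 2 (0.38 log units; beyond the scatter). Compound 2 therefore stands as the lower of the two numbers, with compound 1 as its nearest neighbour and the higher one.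

Compound 3 `Cn1nc(CNC(=O)[C@@H](N)CCSC[C@H]2O[C@@H](n3cnc4c(N)ncnc43)[C@H](O)[C@@H]2O)cc1C1CCC1` keeps everything of compound 2 except at that same place: a group of 10 heavy atoms (8 carbon, 2 nitrogen; one four-membered non-aromatic ring of carbon only, one five-membered aromatic ring with 2 hetero atoms) in place of a group of 10 heavy atoms (7 carbon, 3 nitrogen; one five-membered aromatic ring with 2 hetero atoms, one six-membered non-aromatic ring with 2 hetero atoms), on a saturated chain carbon bound to an amide-type nitrogen. Among the compounds with values here, the only measured step, a 2.4-fold lower number from compound 1 to compound 2 (0.38 log units; beyond the scatter), concerns a different replacement at this position, so it shows that changing this group has shifted the number before, but it gives no direction for the present swap. For compound 3 the expected step is no change at the digits printed from compound 2 to compound 3 (within the scatter), with no change beyond the scatter. In this assay compound 3 is estimated at 50000 nM, in a range from 20000 nM to 130000 nM.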

Compound 3, half-maximal inhibitory concentration: 40000 nM
Estimate against measurement, compound 3: 1.3-fold (0.10 log units) above; the measured number falls inside the stated range.
By their numbers in this assay, from the lowest: compounds 3 and 2 (each within the scatter of the next); then compound 1.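

In this assay the step of a 1.3-fold lower number from compound 2 to compound 3 (0.10 log units; within the scatter) shows that the two groups cannot be told apart, even though the second ring differs: a four-membered ring of carbon only replaces a six-membered non-aromatic ring with 2 hetero atoms, and the group goes from 3 hydrogen-bond acceptors to 2. The step of a 3.0-fold lower number from compound 1 to compound 3 (0.48 log units; beyond the scatter) adds a second comparison with the six-membered aromatic ring of carbon only in compound 1, so among these three compounds, the two that carry a five-membered aromatic ring with 2 hetero atoms both have lower numbers than compound 1, and none goes against this. No further data bear on why the numbers fall this way.

Going by these compounds, it remains open whether the five-membered aromatic ring with 2 hetero atoms is enough on its own, as compound 2 and compound 3 each carry a second ring as well. Also open, on these data alone, is how an open-chain amine or a carboxylic acid in place of that second ring would read, and whether any group at this place can bring the number far lower.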